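Sulfamoyl for Amino on the Shared Core: Cytotoxicity Outlook

The source may report more compounds than this note shows. Statements on the series, on what has been measured and on what is new or still open speak of the compounds shown alone.

Compound 1: `CC(C)Cn1cc(-c2cc(Nc3ccc(OC(F)(F)F)cc3)ncn2)cn1`
Compound 2: `Nc1cccc(-c2cc(Nc3ccc(OC(F)(F)F)cc3)ncn2)c1`

In an ADME assay on BaF3 cells (Mus musculus) for cytotoxicity (a lower number here means that less compound is needed, a higher number that more compound is needed for the effect), compound 1 gives > 10000 nM, which is a limit of the assay rather than a number. Compound 2 likewise gives > 10000 nM, again a limit. The step that the two limits leave unreadable from compound 1 to compound 2 therefore cannot be read, since (the limit of > 10000 nM in this assay, at which 2 of the 2 values shown sit). Within the data shown here, compound 2 thus stands at the limit, with no number of its own, and the only other value beside it is also a limit.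

Compound 3, `NS(=O)(=O)c1cccc(-c2cc(Nc3ccc(OC(F)(F)F)cc3)ncn2)c1`, differs from compound 2 by sulfamoyl in place of amino on an aromatic carbon. Among the measured compounds shown here, no measured step bears on this change: the single step from compound 1 to compound 2 is unreadable because of the limit of > 10000 nM in this assay, at which 2 of the 2 values shown sit, and it concerns a different place on the shared core. With both measured neighbours sitting at the limit, no size or direction of step can be read for the change to compound 3 in this assay. Compound 3 is expected to remain at or beyond the limit, an expected step that the limit leaves unreadable from compound 2 to compound 3. The estimate for compound 3 is 15000 nM, within 5000 nM to 50000 nM.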

Compound 3, half-maximal effective concentration: > 10000 nM
Compound 3: only a limit was reported (the forecaster's own chance of this, stated with the estimate: 85%); the middle value is on the limit's open side.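

In this assay, no step can be read from compound 2 to compound 3, because both compounds rest on a limit of the assay rather than on a number: the limit of > 10000 nM in this assay, at which 3 of the 3 values shown sit.

The compounds shown leave open whether sulfamoyl in place of amino changes this read-out at all, and how far compound 1, compound 2 and compound 3 each lie beyond that limit.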